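The source may hold more compounds than are shown below. What is called first, only, known or untested is meant among the compounds shown, and "the series" means these compounds.

In a toxicity assay on WI-38 cells (Homo sapiens) for inhibition, read by MTT assay, with a stated time of 72 h (on this read-out lower numbers stand for stronger inhibition and higher numbers for weaker inhibition), compound 1 `O=C(NCc1ccc(NC(=O)c2cc(F)ccc2N2CCCC2)cc1)OCc1cccnc1` gives > 100000 nM, which is a limit of the assay and not a number. Its relative, compound 2 `Cc1ccc(C(=O)Nc2ccc(CNC(=O)OCc3cccnc3)cc2)c(N2CCCC2)c1`, gives > 100000 nM, and this too is a limit. So compound 1 stands at the same limit as the only other compound measured, and no true number is known for either.

Compound 3 `O=C(NCc1ccc(NC(=O)c2cc(Br)ccc2N2CCCC2)cc1)OCc1cccnc1` keeps the core of compound 1 and has bromo in place of fluoro on an aromatic carbon, meta to a large group and para to a pyrrolidin-1-yl group: bromo in place of fluoro on an aromatic carbon. Among the measured compounds shown here, no measured step shows what such a swap does in this assay, so no change beyond the usual scatter is expected. The estimated step is a number no higher from compound 1 to compound 3 (the limit leaves the size open). For compound 3 the expected value is 100000 nM, with an estimated range from 40000 nM to 200000 nM.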

Compound 3, half-maximal inhibitory concentration: > 100000 nM
Compound 3: only a limit was reported (the forecaster's own chance of this, stated with the estimate: 80%); the middle value sits exactly at the limit.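

Compound 1 and compound 3 both stand at a limit and not at a number in this assay, so no step can be read between them: the limit of > 100000 nM in this assay, at which 3 of the 3 values shown sit. The compounds shown leave open whether bromo and fluoro differ at all here, and where the true value of each compound lies.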